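Removing the Methylamino Group from Compound 3

The compounds below may be only part of what the source reports. "The series", "measured", "known", "first", "only" and "open" are said of these compounds alone.

In a functional assay on HCT-116 cells (Homo sapiens) for antiproliferative activity, read by MTT assay, with a stated time of 48 h (a higher number here means a weaker inhibitor, a lower number a stronger inhibitor), compound 1 (`CCCCCC(CCO)n1cnc2c(NC)ncnc21`) gives > 50000 nM, which is a limit. Compound 2 (`CCCCCCC(CCO)n1cnc2c(OC)ncnc21`) gives > 50000 nM, also a limit. Compound 3 (`CCCCCCC(CCO)n1cnc2c(NC)ncnc21`) gives > 50000 nM, again a limit, so it has no number of its own. Compound 4 (`CCCCCCC(CCO)n1cnc2cncnc21`) carries hydrogen in place of methylamino on an aromatic carbon. The closest measured change is a step that the two limits leave unreadable from compound 2 to compound 3, with methylamino in place of methoxy on an aromatic carbon. The other is a step that the two limits leave unreadable from compound 1 to compound 3, on the chain. Neither has a readable size, and all the values share one ceiling: the limit of > 50000 nM in this assay, at which 3 of the 3 values shown sit. The expected change is a number no higher from compound 3 to compound 4 (the limit leaves the size open), with no shift beyond the scatter in either direction. Compound 4 is estimated at 50000 nM, with an expected range from 15000 nM to 100000 nM.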

Compound 4, half-maximal inhibitory concentration: > 50000 nM
Compound 4: a limit, no number (the forecaster's own chance of this, stated with the estimate: 85%); the middle value sits exactly at the limit.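

No step can be read from compound 3 or compound 2 to compound 4, since compound 4 also gives only a limit: the limit of > 50000 nM in this assay, at which 4 of the 4 values shown sit.

In this assay the compounds shown leave open how strong any of them actually is and what each change does.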